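Swapping an Isobutyl Chain for a Methoxyethyl Chain

The source may report more compounds than this note shows. Statements on the series, on what has been measured and on what is new or still open speak of the compounds shown alone.

The three measured compounds in an assay on Sf9 cells for inhibition of protein deacetylase HDAC6 (Homo sapiens), read by fluorescence and mobility shift assay; a higher number here means a weaker inhibitor, a lower number a stronger inhibitor:
Compound 1, `O=C(NO)c1ccc(CN(C2CC2)S(=O)(=O)c2cc(F)c(F)c(F)c2F)cc1`, gives 8.5 nM
Compound 2, `CC(C)N(Cc1ccc(C(=O)NO)cc1)Cc1cc(F)c(F)c(F)c1F`, gives 16.2 nM
Compound 3, `CC(C)CN(Cc1ccc(C(=O)NO)cc1)S(=O)(=O)c1cc(F)c(F)c(F)c1F`, gives 24.6 nM

Compound 3 stands highest of these three numbers. Its gap to compound 2 lies within the usual scatter, so those two cannot be told apart. Its gap to compound 1 lies beyond the scatter: a 2.9-fold higher number from compound 1 to compound 3 (0.46 log units; beyond the scatter), a modest loss.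

Compound 4, `COCCN(Cc1ccc(C(=O)NO)cc1)S(=O)(=O)c1cc(F)c(F)c(F)c1F`, has not yet been measured. It differs from compound 3 by methoxymethyl in place of isopropyl on a saturated chain carbon bound to a sulfonamide nitrogen. For the measured compounds named here, no measured pair exchanges a chain carbon for an oxygen, so the only guide is the step from compound 1 to compound 3, which shows that changing the group on this nitrogen shifts the number modestly. A step of similar or smaller size is expected in this assay, in either direction. Compound 4 is therefore expected near 18 nM, between 7 nM and 45 nM. That estimate means an expected step of a 1.4-fold lower number from compound 3 to compound 4 (0.14 log units; within the scatter).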

Compound 4, half-maximal inhibitory concentration: 27.8 nM
For compound 4 the middle estimate is 1.5-fold (0.19 log units) below the measured one; the measured number falls inside the stated range.
By their numbers in this assay, from the lowest: compounds 1, 2, 3 and 4 (each within the scatter of the next, the first and the last beyond it).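

In this assay, exchanging isobutyl for 2-methoxyethyl on the sulfonamide nitrogen swaps a chain carbon for an oxygen and brings in a hydrogen-bond acceptor, yet the result is a 1.1-fold higher number from compound 3 to compound 4 (0.05 log units; within the scatter), so compound 3 and compound 4 cannot be told apart. Cyclopropyl on this nitrogen still gives a separable difference, with a 3.3-fold higher number from compound 1 to compound 4 (0.51 log units; beyond the scatter), so compound 4 joins compound 3 as an open-chain compound with a higher number than compound 1. No measurement available here accounts for these results.

As far as these compounds go, it remains open whether an oxygen elsewhere in the chain, or a longer chain such as 3-methoxypropyl, would also leave the number in place. A chain ending in an amine or a carboxylic acid could behave quite differently at this nitrogen.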